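Pyridin-3-yl amide restored on a chloropyridinyl piperazine

A few compounds are considered here, and "the series" means these few. Any claim that something is new, unique, unknown or untested is made for them only; others in the source may bear on it.

Compound 1 `O=C(CN1CCN(c2ccccn2)CC1)Nc1cccnc1`: 1080 nM
Compound 2 `Cc1cccc(NC(=O)CN2CCN(c3ccc(Cl)cn3)CC2)c1`: "not active" (no number reported)
Compound 3 `CCc1cccc(NC(=O)CN2CCN(c3ccc(Cl)cn3)CC2)c1`: "not active" (no number reported)

Compound 3 stands without a number in a functional assay on cells for agonist activity at D(4) dopamine receptor (Homo sapiens), read by TR-FRET and cAMP accumulation, with a stated time of 30 min (on this read-out higher numbers stand for an effect only at larger amounts of compound and lower numbers for an effect already at smaller amounts), where compound 3 is reported as "not active" (no number reported); compound 2 is likewise reported as "not active" (no number reported), so neither gives a foothold for a size of step. Among the measured compounds only compound 1 gives a number, and in this assay compound 1 gives 1080 nM.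

Compound 4 `O=C(CN1CCN(c2ccc(Cl)cn2)CC1)Nc1cccnc1` differs from compound 3 in one place: pyridin-3-yl in place of 3-ethylphenyl on an amide-type nitrogen. With this change compound 4 carries the same pyridin-3-yl on its amide nitrogen as compound 1, while the rest of compound 4 matches compound 3. A step size cannot be computed from compound 3, but a move from no activity to a measurable number is expected, because compound 1 with the pyridin-3-yl amide gives 1080 nM. For compound 4 an activity near 1500 nM is estimated, between 400 nM and 6000 nM.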

Compound 4, half-maximal effective concentration: "not active" (no number reported)
Nothing numeric was reported for compound 4, and the estimate cannot be compared.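

In this assay compound 3 and compound 4 both stand without a number, so no step can be read between them. No measurement at hand bears on this result. The compounds shown leave open why compound 4 gives no number while compound 1 gives 1080 nM.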